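Pyridin-3-yl for pyridin-4-yl: an expected small step

The source may hold more compounds than are shown below. What is called first, only, known or untested is meant among the compounds shown, and "the series" means these compounds.

Measured compounds:
compound 1 `c1ccc(-c2[nH]c3ccccc3c2C2CC(c3ccncc3)=NO2)cc1` gives 70.5 ug/mL
compound 2 `O=C(c1ccccc1)N1N=C(c2cccnc2)CC1c1c(-c2ccccc2)[nH]c2ccccc12` gives 50.3 ug/mL
compound 3 `O=C(c1ccccc1)N1N=C(c2ccncc2)CC1c1c(-c2ccccc2)[nH]c2ccccc12` gives 52.5 ug/mL

These three compounds were measured in a functional assay, read by Griess assay, in phosphate buffer, with a stated time of 90 min, in the presence of a further agent that is not named here; on this read-out higher numbers stand for weaker inhibition and lower numbers for stronger inhibition. Compound 1 gives the highest of the three numbers, but its gaps to compound 3 and to compound 2 are both within the scatter of this assay, so no order among them can be read. Compound 2 and compound 3 share one core and differ only by pyridin-3-yl in place of pyridin-4-yl on a carbon with a double bond to nitrogen. That step, a 1.0-fold lower number from compound 3 to compound 2 (0.02 log units; within the scatter), is as small as a step can be.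

Compound 4, `c1ccc(-c2[nH]c3ccccc3c2C2CC(c3cccnc3)=NO2)cc1`, has not yet been measured in this assay. It is related to compound 1 by pyridin-3-yl in place of pyridin-4-yl on a carbon with a double bond to nitrogen. The cores of compound 1 and compound 3 are not the same, and the difference between the two cores is not broken down here. The place lines of the two changes also differ: in compound 3 and compound 2 the carbon sits in a five-membered non-aromatic ring with 2 nitrogen, two ring bonds from the ring nitrogen and two ring bonds from the ring atom that bears a benzoyl group, whereas in compound 1 and compound 4 the ring holds 1 nitrogen and 1 oxygen and the carbon sits two ring bonds from the ring oxygen. The change is therefore the same kind of change, not the same.

For the measured compounds named here, the expectation for compound 4 rests on the one measured instance of this kind of change, where a 1.0-fold lower number from compound 3 to compound 2 (0.02 log units; within the scatter), and on the value of compound 1, 70.5 ug/mL. Compound 4 is accordingly expected to show a 1.0-fold lower number from compound 1 to compound 4 (0.02 log units; within the scatter), a step within the scatter. Compound 4 is estimated at 68 ug/mL, with a plausible range from 40 ug/mL to 120 ug/mL.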

Compound 4, half-maximal inhibitory concentration: 117 ug/mL
Compound 4: middle estimate off by 1.7-fold (0.24 log units), on the low side, and the stated range covers the measured number.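

In this assay, pyridin-3-yl in place of pyridin-4-yl on the five-membered non-aromatic ring with 1 nitrogen and 1 oxygen gives a 1.7-fold higher number from compound 1 to compound 4 (0.22 log units; within the scatter), so the step on this core, like the earlier one, cannot be read as a real change. Set side by side, the two steps give no sign that this change behaves differently on the two cores: the same change on two cores in this assay, a 1.0-fold lower number (0.02 log units; within the scatter) from compound 3 to compound 2 and a 1.7-fold higher number (0.22 log units; within the scatter) from compound 1 to compound 4, 1.7-fold (0.24 log units) apart, within the scatter of two such steps. This shows only that, on these two cores, moving between pyridin-4-yl and pyridin-3-yl leaves the number within the usual scatter; it does not show that the change carries over exactly, as a single pair on each core cannot exclude a difference smaller than the scatter, and two cores do not make a rule for the whole series.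

The compounds shown leave open whether a pyridin-2-yl group, an amine or a carboxylic acid on this same carbon would produce a step beyond the scatter. They also leave open how much the benzoyl group and the other differences between the two cores contribute on their own, as no pair shown isolates any of these differences.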